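Double-bond configuration in compound 2 and compound 3

The compounds below may be only part of what the source reports. "The series", "measured", "known", "first", "only" and "open" are said of these compounds alone.

In a functional assay on PC-3 cells (Homo sapiens) for antiproliferative activity, read by WST assay, with a stated time of 72 h (on this read-out higher numbers stand for an effect only at larger amounts of compound and lower numbers for an effect already at smaller amounts), compound 1 (`CCCCCCCC/C=C\c1c(C)cc(C)nc1CCCOC`) gives > 30 uM as a limit of the assay and not a number. Among the compounds with values here, compound 2 (`CCCCCCCC/C=C\c1c(C)c(/C=C\CCCCCCCC)c2[n+](c1C)CCC2`) gives 1.1 uM as the only actual number so far. Compound 3 (`CCCCCCCC/C=C/c1c(C)c(/C=C/CCCCCCCC)c2[n+](c1C)CCC2`) is not yet measured, and its difference from compound 2 is purely one of configuration (the two compounds have the same atoms and bonds and differ only in configuration as drawn: 2 of 2 stereo elements differ; a double bond is drawn Z in compound 2 and E in compound 3; a double bond is drawn Z in compound 2 and E in compound 3) with both double bonds drawn Z in compound 2 and drawn E in compound 3. No measured step sizes such a change, so from compound 2 at 1.1 uM no shift beyond the scatter is expected in this assay and no direction is favoured. The expected change is a 1.2-fold higher number from compound 2 to compound 3 (0.07 log units; within the scatter) and lies within the scatter. Compound 3 is estimated at 1.3 uM with an expected range from 0.5 uM to 3.5 uM in this assay.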

Compound 3, concentration for half-maximal effect: 0.6 uM
Compound 3: middle estimate off by 2.2-fold (0.34 log units), on the high side, and the stated range covers the measured number.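

In this assay the series now has its first measured step, a 1.8-fold lower number from compound 2 to compound 3 (0.26 log units; within the scatter), so on this read-out the two configurations cannot be told apart. Changing both double bonds from Z to E is therefore sized for the first time, with no other structural change involved: the fact that compounds 2 and 3 differ only in the configuration as drawn

Only the case with both double bonds changed together is shown, so the effect of changing a single double bond remains open. Also open, from the compounds shown here alone, is how the read-out responds to a fully saturated chain, a shorter chain, or a chain ending in an amine or a carboxylic acid.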